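Working notes: from compound 3 to compound 4

This account rests on a few compounds, and the source may have more. Where it says the series, first, only, none or still open, it means among the compounds named here.

In a physicochemical assay for solubility, measured as kinetic solubility (a lower number here means a less soluble compound, a higher number a more soluble compound), compound 3 `Cc1cc(C)c(CN2CCc3c(Cl)cc([C@H](C)CO)c(Cl)c3C2=O)c(=O)[nH]1` gives 131000 nM, the lowest of the three numbers in hand. Compound 1 `Cc1cc(C)c(CN2CCc3c(Cl)cc([C@H](CO)[C@@H]4CCCO4)c(Cl)c3C2=O)c(=O)[nH]1` gives 400000 nM and compound 2 `Cc1cc(C)c(CN2CCc3c(Cl)cc([C@@H](CO)[C@@H]4CCOC4)c(Cl)c3C2=O)c(=O)[nH]1` gives 537000 nM. These two values lie within the scatter of each other, with a 1.3-fold higher number from compound 1 to compound 2 (0.13 log units; within the scatter).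

Compound 4 `Cc1cc(C)c(CN2CCc3c(Cl)cc([C@@H](CO)[C@H]4CCCO4)c(Cl)c3C2=O)c(=O)[nH]1` swaps the methyl of compound 3 for a ring: oxolan-2-yl in place of methyl on a saturated chain carbon bound to an aromatic carbon and a saturated chain carbon. It carries the oxolan-2-yl group of compound 1, with the opposite configuration at both stereocentres of the side chain. For the measured compounds named here, no measured pair shows what such an inversion does.

Going by the values given here, two measured steps bear on the change when read in reverse: a 3.1-fold lower number from compound 1 to compound 3 (0.48 log units; beyond the scatter) and a 4.1-fold lower number from compound 2 to compound 3 (0.61 log units; beyond the scatter). Both are modest and beyond the scatter. A step of similar size towards a higher number is therefore expected in this assay. The estimated step is a 3.1-fold higher number from compound 3 to compound 4 (0.48 log units; beyond the scatter). For compound 4 the estimate is 400000 nM, with an expected range of 220000 nM to 700000 nM.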

Compound 4, solubility: 576000 nM
For compound 4 the middle estimate is 1.4-fold (0.16 log units) below the measured one, within the range that was stated.
By their numbers in this assay, from the lowest: compound 3; then compounds 1, 2 and 4 (each within the scatter of the next).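

In this assay, the oxolan-2-yl group on this saturated chain carbon also stands beyond the scatter from methyl, a 4.4-fold higher number from compound 3 to compound 4 (0.64 log units; beyond the scatter), so all three ring-bearing compounds now separate from compound 3. Moving between oxolan-2-yl and oxolan-3-yl at this place gives no separation, a 1.1-fold higher number from compound 2 to compound 4 (0.03 log units; within the scatter). Inverting both stereocentres gives none either, a 1.4-fold higher number from compound 1 to compound 4 (0.16 log units; within the scatter), and this pair tests configuration alone: the fact that compounds 1 and 4 differ only in the configuration as drawn

The compounds shown leave open whether the step from methyl follows the ring oxygen or simply the larger group, a question that cyclopentyl at the same carbon would address. As far as these compounds go, how an amine or a carboxylic acid on this saturated chain carbon would read in this assay also remains open.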